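From a Limit Towards a Bromo-Methoxy Benzyl Amide

The compounds below may be only part of what the source reports. "The series", "measured", "known", "first", "only" and "open" are said of these compounds alone.

Measured in a functional assay on PC-3 cells (Homo sapiens) for antiproliferative activity, read by MTT assay, with a stated time of 48 h; a higher number here means a weaker inhibitor, a lower number a stronger inhibitor:
- compound 1 `COc1ccc(CN(C(=O)CSc2nc3ccccc3s2)c2cc(OC)c(OC)c(OC)c2)cc1C`: 34300 nM
- compound 2 `COc1ccc(CN(C(=O)CSc2nc3ccccc3s2)c2cc(OC)c(OC)c(OC)c2)cc1`: 8460 nM
- compound 3 `COc1cc(N(Cc2ccc(Cl)cc2)C(=O)CSc2nc3ccccc3s2)cc(OC)c1OC`: > 80000 nM (a limit, not a number)

Compound 3 stands only at a limit, > 80000 nM. The next compound, compound 4 `COc1ccc(CN(C(=O)CSc2nc3ccccc3s2)c2cc(OC)c(OC)c(OC)c2)cc1Br`, has 3-bromo-4-methoxyphenyl in place of 4-chlorophenyl on a saturated chain carbon bound to an amide-type nitrogen. Two measured steps run opposite to this change: an at least 2.3-fold higher number from compound 1 to compound 3 (0.36 log units; beyond the scatter) and an at least 9.4-fold higher number from compound 2 to compound 3 (0.97 log units; beyond the scatter). Both lie beyond the scatter, so a move back to a lower number is expected in this assay. How far it goes depends on the extra ring group, since hydrogen in place of methyl gave a 4.1-fold lower number from compound 1 to compound 2 (0.61 log units; beyond the scatter). Among the measured compounds shown here, the 3-bromo-4-methoxyphenyl group of compound 4 most resembles the 4-methoxy-3-methylphenyl group of compound 1, which gives 34300 nM, so the expectation stays nearer that value than the one for compound 2. The expected change is an at least 3.2-fold lower number from compound 3 to compound 4 (0.50 log units; beyond the scatter), a modest step. For compound 4 the estimated value is 25000 nM, with an expected range of 7000 nM to 70000 nM.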

Compound 4, half-maximal inhibitory concentration: 16000 nM
The estimate for compound 4 lay 1.6-fold (0.19 log units) above the measured number; low and high end bracket the measured number.
By their numbers in this assay, from the lowest: compounds 2 and 4 (each within the scatter of the next); then compound 1. At a limit, above all of these: compound 3.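

In this assay, the 3-bromo-4-methoxyphenyl group on the saturated chain carbon bound to an amide-type nitrogen brings the number down from where compound 3 stands, with an at least 5.0-fold lower number from compound 3 to compound 4 (0.69 log units; beyond the scatter), a step read from a limit: the limit of > 80000 nM in this assay, at which 1 of the 4 values shown sits.

Bromo in place of hydrogen leaves compound 4 not distinguishable from compound 2, with a 1.9-fold higher number from compound 2 to compound 4 (0.28 log units; within the scatter). Bromo in place of methyl gives a 2.1-fold lower number from compound 1 to compound 4 (0.33 log units; beyond the scatter), so on this aromatic carbon the methyl of compound 1 is set apart from both other groups, though only by modest steps.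

What the compounds shown leave open is whether an amine or a carboxylic acid on that aromatic carbon would move the number in either direction. On these data alone, it also remains open whether a hydroxyl in place of the methoxy group would keep the number clear of the limit.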